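Swapping a halogen on two related cytotoxic scaffolds

This account rests on a few compounds, and the source may have more. Where it says the series, first, only, none or still open, it means among the compounds named here.

The account begins with compound 1 `COc1cc(/C=C2\CN(C)C/C(=C\c3ccc(Cl)cc3)C2=O)cc(OC)c1OC`, which in a functional assay on HepG2 cells (Homo sapiens) for cytotoxicity, read by MTT assay, with a stated time of 24 h (a lower number here means a stronger inhibitor, a higher number a weaker inhibitor), gives 8250 nM. Compound 2 `COc1cc(/C=C2\CN(C)C/C(=C\c3ccc(Br)cc3)C2=O)cc(OC)c1OC` differs from it by bromo in place of chloro on an aromatic carbon, and in this assay compound 2 gives 6800 nM. The step between these two measured compounds is a 1.2-fold lower number from compound 1 to compound 2 (0.08 log units; within the scatter), so the two values cannot be told apart with confidence.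

Compound 3 `CN1C/C(=C\c2ccc(Cl)cc2)C(=O)/C(=C/c2cccc([N+](=O)[O-])c2)C1` carries a different core; how its core differs from that of compound 1 is not broken down here. In this assay compound 3 gives 8210 nM, a number that sits within the scatter of the values of compound 1 and compound 2, so no order among the three measured compounds can be claimed.

Compound 4 `CN1C/C(=C\c2ccc(Br)cc2)C(=O)/C(=C/c2cccc([N+](=O)[O-])c2)C1` has not yet been measured. It differs from compound 3 by bromo in place of chloro on an aromatic carbon, the same change that separates compound 2 from compound 1, made at a place described in identical words on both cores. For the measured compounds named here, the only evidence for what this change does is the step from compound 1 to compound 2, and that step lies within the scatter. On this basis the step expected is a 1.2-fold lower number from compound 3 to compound 4 (0.08 log units; within the scatter), because the measured step of a 1.2-fold lower number from compound 1 to compound 2 (0.08 log units; within the scatter) gives no reason to expect anything larger. Compound 4 is therefore estimated at 6900 nM, with a likely range from 3500 nM to 13500 nM.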

Compound 4, half-maximal inhibitory concentration: 8800 nM
For compound 4 the middle estimate is 1.3-fold (0.11 log units) below the measured one, and the stated range covers the measured number.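

Bromo in place of chloro on the second core gives a 1.1-fold higher number from compound 3 to compound 4 (0.03 log units; within the scatter) in this assay, so on this core, as on the first, the change produces no step that can be told apart from the scatter. Set beside each other, the two steps do not differ in any way these numbers can resolve: the same change on two cores in this assay, a 1.2-fold lower number (0.08 log units; within the scatter) from compound 1 to compound 2 and a 1.1-fold higher number (0.03 log units; within the scatter) from compound 3 to compound 4, 1.3-fold (0.11 log units) apart, within the scatter of two such steps What this shows is that, for compound 1 to compound 2 and for compound 3 to compound 4 alike, the 4-chlorophenyl to 4-bromophenyl change leaves the number indistinguishable from where it started; it does not show that the change has exactly the same effect on both cores, since a small effect could lie hidden inside the scatter of either step, and two cores are too few to support a rule for the whole series.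

The compounds shown leave open whether any group other than these two halogens at this place on the aromatic ring would move the number at all, such as fluoro, a methoxy group, an amine or a carboxylic acid. They also leave open whether a longer chain at the same place would bring a step beyond the scatter on either core.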